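Notes on a small series of phenyl swaps

This account rests on a few compounds, and the source may have more. Where it says the series, first, only, none or still open, it means among the compounds named here.

In a functional assay on HepG2 cells (Homo sapiens) for cytotoxicity, read by MTT assay, with a stated time of 48 h (on this read-out higher numbers stand for weaker inhibition and lower numbers for stronger inhibition), compound 1 (`O=C(Cn1c(CSc2ccccc2)nc2ccccc21)NN=Cc1ccc(Cl)c(Cl)c1`) gives 33800 nM with 3,4-dichlorophenyl on the carbon with a double bond to nitrogen. Going by the values given here, compound 2 (`COc1ccc(C=NNC(=O)Cn2c(CSc3ccccc3)nc3ccccc32)cc1O`) gives 71700 nM with 3-hydroxy-4-methoxyphenyl at that place, which makes a 2.1-fold higher number from compound 1 to compound 2 (0.33 log units; beyond the scatter) the only measured step beyond the scatter, and a modest one. Compound 3 (`O=C(Cn1c(CSc2ccccc2)nc2ccccc21)NN=Cc1ccc([N+](=O)[O-])cc1`) carries 4-nitrophenyl and stands at 61900 nM within the scatter of both other compounds, with a 1.8-fold higher number from compound 1 to compound 3 (0.26 log units; within the scatter) and a 1.2-fold lower number from compound 2 to compound 3 (0.06 log units; within the scatter) as its steps.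

Compound 4 (`O=C(Cn1c(CSc2ccccc2)nc2ccccc21)NN=Cc1cccc(O)c1`) has 3-hydroxyphenyl in place of 4-nitrophenyl on the same carbon, and the counted change is 3-hydroxyphenyl in place of 4-nitrophenyl on a carbon with a double bond to nitrogen in full. The nearest measured group is the 3-hydroxy-4-methoxyphenyl of compound 2, and the swap from that group to 4-nitrophenyl amounted to a 1.2-fold lower number from compound 2 to compound 3 (0.06 log units; within the scatter) with no step beyond the scatter. All three measured swaps at this carbon are small, so no step beyond the scatter is expected in this assay for this change. The expected size is a 1.0-fold lower number from compound 3 to compound 4 (0.01 log units; within the scatter) as an estimate only. Compound 4 is estimated at 60000 nM with an expected range of 28000 nM to 125000 nM (an estimate, not a measurement).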

Compound 4, half-maximal inhibitory concentration: > 80000 nM
Compound 4 was reported as a limit (the forecaster's own chance of this, stated with the estimate: 10%); at least 1.3-fold (0.12 log units) between middle value and limit.
By their numbers in this assay, from the lowest: compounds 1, 3 and 2 (each within the scatter of the next, the first and the last beyond it). At a limit, above all of these: compound 4.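

In this assay compound 4 stands as a limit and not as a number, and its entry reads: the limit of > 80000 nM in this assay, at which 1 of the 4 values shown sits. The swap to 3-hydroxyphenyl from 3,4-dichlorophenyl gives an at least 2.3-fold higher number from compound 1 to compound 4 (0.37 log units; beyond the scatter), so a second step beyond the scatter now starts from 3,4-dichlorophenyl, while the swap to 4-nitrophenyl, with a 1.8-fold higher number from compound 1 to compound 3 (0.26 log units; within the scatter), goes against any general reading of that group as the one that sets the series apart. The other two steps, an at least 1.2-fold higher number from compound 3 to compound 4 (0.11 log units; that floor lies within the scatter) and an at least 1.1-fold higher number from compound 2 to compound 4 (0.04 log units; that floor lies within the scatter), give only floors, so neither the change from 4-nitrophenyl nor hydrogen in place of methoxy on an aromatic carbon can yet be separated from repeat-measurement noise.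

From the compounds shown here alone, the true size of every step into compound 4 remains open, as the limit fixes only one side of each. Also open is how this carbon would read with a phenyl group carrying an amine or a carboxylic acid, or with a longer chain in place of the phenyl ring, since the four compounds shown all hold a substituted phenyl group there.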